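This account rests on a few compounds, and the source may have more. Where it says the series, first, only, none or still open, it means among the compounds named here.

Measured so far in an ADME assay on S9 fraction from liver (Rattus norvegicus) for metabolic stability, read by LC-MS, using NADPH, with a stated time of 60 min, tested at 10 uM; on this read-out lower numbers stand for a less stable compound and higher numbers for a more stable compound:
- compound 1, `C[C@@H](O)Cc1cc(-c2ccnc3[nH]nc(C(F)(F)F)c23)cc(C2(C#N)CC2)c1`: 42%
- compound 2, `C[C@H](O)Cc1cc(-c2ccnc3[nH]nc(C(F)(F)F)c23)cc(C2(C#N)CC2)c1`: 37%
- compound 3, `COCCc1cc(-c2ccnc3[nH]nc(C(F)(F)F)c23)cc(C2(C#N)CC2)c1`: 90%

Compound 2 stands lowest of the three numbers. Compound 1 and compound 2 share the same atoms and bonds and differ only in configuration as drawn (the fact that compounds 1 and 2 differ only in the configuration as drawn); the step of a number 5 percentage points lower from compound 1 to compound 2 (within the scatter) stays within the scatter, so no order between these two is claimed. Compound 3 stands well apart: a number 48 percentage points higher from compound 1 to compound 3 (beyond the scatter) and a number 53 percentage points higher from compound 2 to compound 3 (beyond the scatter) are both large and beyond the scatter, each with methoxymethyl in place of 1-hydroxyethyl on a saturated chain carbon bound to an aromatic carbon.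

Not yet measured is compound 4, `CCc1cc(-c2ccnc3[nH]nc(C(F)(F)F)c23)cc(C2(C#N)CC2)c1`. Against compound 2 the change is methyl in place of 1-hydroxyethyl on a saturated chain carbon bound to an aromatic carbon.

Within the data shown here, the steps that bear on this are the two in which the 1-hydroxyethyl leaves, a number 53 percentage points higher from compound 2 to compound 3 (beyond the scatter) and a number 48 percentage points higher from compound 1 to compound 3 (beyond the scatter); the configuration step a number 5 percentage points lower from compound 1 to compound 2 (within the scatter) adds nothing beyond the scatter. Both informative steps were large and upward in this assay. A methyl is a smaller entering group than methoxymethyl, and whether a plain ethyl chain behaves like the methoxymethyl chain is not shown by these three compounds, so the expectation is an upward step of substantial size but with a wide range. Compound 4 is expected to give about 72%, between 48% and 92%, which would mean an estimated step of a number 35 percentage points higher from compound 2 to compound 4 (beyond the scatter).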

Compound 4, percent of the compound remaining: 78%
Compound 4: the middle estimate sits 6 percentage points below what was measured; the measured number falls inside the stated range.
By their numbers in this assay, from the lowest: compounds 2 and 1 (each within the scatter of the next); then compound 4; then compound 3.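

In this assay, compound 4 shows that the high number of compound 3 does not depend on the methoxy: methyl in place of 1-hydroxyethyl gives a number 41 percentage points higher from compound 2 to compound 4 (beyond the scatter) and a number 36 percentage points higher from compound 1 to compound 4 (beyond the scatter), both large steps. The methoxy still counts for something, since hydrogen in its place gives a number 12 percentage points lower from compound 3 to compound 4 (beyond the scatter), a modest step beyond the scatter, so a chain with no oxygen keeps most but not all of the rise seen with compound 3. The two large steps to compound 4 start from a single structure in two drawn configurations, so the rise appears with either form of the stereocentre that leaves with the 1-hydroxyethyl: the fact that compounds 1 and 2 differ only in the configuration as drawn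

Whether the low numbers of compound 1 and compound 2 go with the hydroxyl itself or with the rest of the 2-hydroxypropyl chain stays open, as the compounds shown change both at once. A 2-hydroxyethyl chain, a longer chain such as propyl, or an amine in place of the methoxy would each add a separate reading on how this position behaves in this assay.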